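The source may hold more compounds than are shown below. What is called first, only, known or untested is meant among the compounds shown, and "the series" means these compounds.

Measured so far: compound 1 `O=c1ccn(COC(CO)CO)c(=O)[nH]1` and compound 2 `Cc1cc(=O)[nH]c(=O)n1COC(CO)CO`.

In a functional assay on Vero cells (Chlorocebus sabaeus) for cytotoxicity (on this read-out lower numbers stand for higher toxicity in this test and higher numbers for lower toxicity in this test), compound 1 reaches only a limit, > 462000 nM. In this assay compound 2 likewise stops at a limit, > 434000 nM. Among the compounds with values here, the one measured step, a step that the two limits leave unreadable from compound 1 to compound 2, rests on two limits, the limit of > 434000 nM in this assay, at which 1 of the 2 values shown sits, and (the limit of > 462000 nM in this assay, at which 1 of the 2 values shown sits), and so has no readable size. Compound 2 thus stands at a limit without a number. Compound 3 `Cc1c(Br)c(=O)[nH]c(=O)n1COC(CO)CO` differs from compound 2 by bromo in place of hydrogen on an aromatic carbon. Within the data shown here, no measured step bears on this change. Compound 3 is therefore expected again near a limit, 400000 nM with range 150000 nM to 500000 nM. The expected step of an at least 1.0-fold lower number from compound 2 to compound 3 (0.03 log units; that floor lies within the scatter) stays within the scatter.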

Compound 3, half-maximal cytotoxic concentration: > 324000 nM
Compound 3 was reported as a limit; the forecaster's own chance of this, stated with the estimate: 70%; the middle value does not contradict the limit.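

Compound 2 and compound 3 both stop at limits, so the step between them cannot be read. Left open is whether bromo in place of hydrogen on an aromatic carbon shifts the read-out in this assay at all.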